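The source may report more compounds than this note shows. Statements on the series, on what has been measured and on what is new or still open speak of the compounds shown alone.

Measured so far:
compound 1 `C=CCC/C(C)=N\Nc1nc(-c2cccc([N+](=O)[O-])c2)cs1` — 101 nM
compound 2 `CCCC/C(C)=N\Nc1nc(-c2cccc([N+](=O)[O-])c2)cs1` — 118 nM

In an assay on isolated protein for inhibition of Amine oxidase [flavin-containing] B (Homo sapiens), read by fluorescence, with a stated time of 20 min (on this read-out higher numbers stand for weaker inhibition and lower numbers for stronger inhibition), compound 2 gives 118 nM, the highest of the two numbers; its nearest neighbour is compound 1 at 101 nM, and the step of a 1.2-fold higher number from compound 1 to compound 2 (0.07 log units; within the scatter) is within the scatter.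

Compound 3 `CCC/C(CC)=N\Nc1nc(-c2cccc([N+](=O)[O-])c2)cs1` is to be measured in this assay. It has the same atoms as compound 2, joined differently: a group of 7 heavy atoms (6 carbon, 1 nitrogen; no ring) in place of a group of 7 heavy atoms (6 carbon, 1 nitrogen; no ring), on a nitrogen on an aromatic ring. Among the compounds with values here, no measured pair shows a rearrangement of this kind. Within the data shown here, the only step available, a 1.2-fold higher number from compound 1 to compound 2 (0.07 log units; within the scatter), concerns a change on the same side chain and stays within the scatter, so there is no evidence that a small alteration of this chain moves the number.

Compound 3 is therefore expected to stay close to compound 2, with the step of a 1.1-fold higher number from compound 2 to compound 3 (0.03 log units; within the scatter) estimated as none beyond the scatter. The estimate for compound 3 is 125 nM, with a range from 55 nM to 280 nM.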

Compound 3, half-maximal inhibitory concentration: 189 nM
Estimate against measurement, compound 3: 1.5-fold (0.18 log units) below, and the stated range covers the measured number.
By their numbers in this assay, from the lowest: compounds 1, 2 and 3 (each within the scatter of the next).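

In this assay, exchanging one group of 7 heavy atoms (6 carbon, 1 nitrogen; no ring) for another built from the same atoms, on a nitrogen on an aromatic ring, gives a 1.6-fold higher number from compound 2 to compound 3 (0.20 log units; within the scatter), while the comparison with the unsaturated side chain gives a 1.9-fold higher number from compound 1 to compound 3 (0.27 log units; within the scatter). A reshuffling of atoms within this group, and not only a change at the end of the chain, thus leaves compound 1, compound 2 and compound 3 unranked, so the position has so far accepted all three groups. Nothing measured independently bears on these small differences.

Still open, on these data alone, is whether any group at this position moves the number beyond the scatter. An amine, a carboxylic acid, a phenyl ring or a much longer chain on the same carbon would test that.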